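A few compounds are considered here, and "the series" means these few. Any claim that something is new, unique, unknown or untested is made for them only; others in the source may bear on it.

Working notes on the series.

Two compounds carry measurements. Compound 1, `Fc1ccc(NCn2nc(-c3ccc4c(c3)OCCO4)oc2=S)cc1`, in a functional assay, with a stated time of 6 min (on this read-out higher numbers stand for weaker inhibition and lower numbers for stronger inhibition), gives 6480 nM. Compound 2, `FC(F)(F)c1ccccc1NCn1nc(-c2ccc3c(c2)OCCO3)oc1=S`, in this assay gives 9220 nM. The two values lie within the usual scatter of each other, so compound 1 cannot be set apart from compound 2 on these numbers; the pair only shows that the shared core with an arylamino-methyl substituent sits in the micromolar region of this assay.

Compound 3, `S=c1oc(-c2ccc3c(c2)OCCO3)nn1CNc1cccc(Br)c1`, is the next compound to be measured in this assay. Relative to compound 1 the change is 3-bromophenyl in place of 4-fluorophenyl on an amine nitrogen. For the measured compounds named here, no measured pair isolates this change, so the size and direction of the step cannot be read from earlier data. With two measured compounds lying close together and no guide for a halogen exchange on the phenyl, the expectation for compound 3 is a step of a 1.1-fold lower number from compound 1 to compound 3 (0.03 log units; within the scatter), not beyond the scatter in either direction.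

Compound 3 is therefore estimated at 6000 nM in this assay, with a range from 2500 nM to 15000 nM.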

Compound 3, half-maximal inhibitory concentration: 10800 nM
For compound 3 the middle estimate is 1.8-fold (0.26 log units) below the measured one, and the stated range covers the measured number.
By their numbers in this assay, from the lowest: compounds 1, 2 and 3 (each within the scatter of the next).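

For the compounds shown here, the exchange of 4-fluorophenyl for 3-bromophenyl on the amine nitrogen gives a 1.7-fold higher number from compound 1 to compound 3 (0.22 log units; within the scatter) in this assay and is the first step read at this position. This position therefore accepts the change without a step that can be told from the scatter, and the micromolar level of compound 1 holds in compound 3 with a bromine on the phenyl. The change alters the halogen and its numbered ring position together, so this single step cannot assign any part of the difference to either one, and no measurement bears on the size of the step.

A 3-fluorophenyl or 4-bromophenyl group at this position would separate the halogen from its ring position. Also open, going by these compounds, is whether the unsubstituted phenyl, a methoxy-bearing phenyl, a phenyl carrying a carboxylic acid or a saturated ring such as cyclohexyl on the amine nitrogen would move the number in this assay beyond the scatter.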